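The source may report more compounds than this note shows. Statements on the series, on what has been measured and on what is new or still open speak of the compounds shown alone.

Compound 1 `CCn1c(CN2CCN(C(=O)C3CC3)CC2)nc2ccccc21` gives 20.8% in an assay on isolated protein for inhibition of aldehyde dehydrogenase 1A1 (Homo sapiens), read by spectrophotometry, tested at 10 uM; on this read-out lower numbers stand for less inhibition and higher numbers for more inhibition at the one concentration tested (going by the name of the read-out).
Compound 2 `Cc1cccc(Cn2c(OC3CCN(C(=O)C4CC4)CC3)nc3ccccc32)c1` gives 80.6%.
Compound 3 `Cc1cccc(Cn2c(CN3CCN(C(=O)c4ccc(C(C)C)cc4)CC3)nc3ccccc32)c1` gives 67.6%.

Of the three measured compounds, compound 1 stands lowest in this assay: compound 3 lies closest to it, at a distance beyond the usual scatter, and compound 2 lies furthest away, also beyond the scatter. Both of the compounds with the higher numbers carry a larger group on the aromatic nitrogen than the ethyl of compound 1, though nothing else ties these three together in single steps.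

Compound 4 `O=C(C1CC1)N1CCN(Cc2nc3ccccc3n2Cc2ccc(F)cc2)CC1` has not been measured. It is built from compound 1 by one change: 4-fluorophenyl in place of methyl on a saturated chain carbon bound to an aromatic nitrogen. Read one bond further out, this is ethyl to 4-fluorobenzyl on the same aromatic nitrogen.

Given that compounds 2 and 3, each with a benzyl-type group on that nitrogen, sit far above compound 1, the step from compound 1 to compound 4 is expected to be an increase of about a number 34.2 percentage points higher from compound 1 to compound 4 (beyond the scatter), well beyond the scatter. Compound 4 is therefore estimated at 55%, with a range from 30% to 80%; only compounds 2 and 3 support this expectation, and neither shares the exact change.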

Compound 4, a percentage reported as inhibition, at one concentration (the size of the read-out at that concentration, not a potency): 32.7%
For compound 4 the middle estimate is 22.3 percentage points above the measured one; the measured number falls inside the stated range.
By their numbers in this assay, from the lowest: compound 1; then compound 4; then compound 3; then compound 2.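

For the compounds shown here, the change from ethyl to 4-fluorobenzyl on the aromatic nitrogen gives a number 11.9 percentage points higher from compound 1 to compound 4 (beyond the scatter) in this assay, the first reading of this position through a single change, since the earlier compounds differed from one another in more than one place. It shows that this larger group alone raises the number beyond the scatter, though only modestly. No measurement shown here accounts for the size of this step.

Still open, going by these compounds, is how plain benzyl or a longer chain such as propyl would compare on this nitrogen, which would separate the part played by the fluorine from that of the ring. Also open, on these data alone, is whether the same change would give a similar step if the cyclopropyl carbonyl of compound 1 were replaced by another acyl group.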